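A few compounds are considered here, and "the series" means these few. Any claim that something is new, unique, unknown or untested is made for them only; others in the source may bear on it.

The series rests on a shared core carrying a urea; compound 1 `C[C@@H](NC(=O)Nc1ccccc1C(C)(C)C)c1ccccc1` and compound 2 `C[C@H](NC(=O)Nc1ccccc1C(C)(C)C)c1ccccc1` differ only in the configuration as drawn at the saturated chain carbon, and compound 3 `C[C@@H](NC(=O)Nc1ccccc1Br)c1ccccc1` carries bromo where compound 1 carries tert-butyl. In an ADME assay on the whole organism with Oryza sativa as the target, tested at 1 uM (a higher number here means a weaker effect of the compound at the concentration tested, a lower number a stronger effect), compound 1 gives 95%, compound 2 gives 99% and compound 3 gives 100%. All three numbers lie within the scatter of one another: the step of a number 4 percentage points higher from compound 1 to compound 2 (within the scatter) and the step of a number 5 percentage points higher from compound 1 to compound 3 (within the scatter) are both small, and the closeness of the first of these fits with the fact that compounds 1 and 2 differ only in the configuration as drawn. Compound 2 thus sits amid the measured values, nearest to compound 3 and furthest from compound 1, with neither gap beyond the scatter.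

Compound 4 `C[C@H](NC(=O)Nc1ccccc1I)c1ccccc1` is reached from compound 2 by iodo in place of tert-butyl on an aromatic carbon. Going by the values given here, the measured step that bears on it is the one from compound 1 to compound 3, where a halogen likewise replaced tert-butyl on the aromatic carbon, and that step stayed within the scatter. The step from compound 2 to compound 4 is therefore expected to be of the same kind, a number 1 percentage points lower from compound 2 to compound 4 (within the scatter), with no change beyond the scatter. Compound 4 is accordingly estimated to give 98% in this assay, within a range from 90% to 100%.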

Compound 4, a percentage reported as activity, at one concentration (the size of the read-out at that concentration, not a potency): 100%
Beside the measured number, compound 4's estimate is 2 percentage points below it; low and high end bracket the measured number.
By their numbers in this assay, from the lowest: compounds 1, 2, 3 and 4 (each within the scatter of the next).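

In this assay, the exchange of tert-butyl for iodo at this place, on an aromatic carbon ortho to a large group, gives the step of a number 1 percentage points higher from compound 2 to compound 4 (within the scatter). The earlier compounds shown here showed a halogen at this place only as bromo and only with the configuration of compound 1, whereas this step extends the exchange to iodo and to the configuration of compound 2. Here a group of 4 heavy atoms gives way to 1 heavy atom without a step beyond the scatter, but nothing available explains why the two numbers stay so close.

The compounds shown leave open whether any group at this place can move the number in this assay beyond the scatter, since every step shown so far stays within it, and an amine, a carboxylic acid or a longer chain at this aromatic carbon would test that directly. They also leave open whether iodo with the configuration of compound 1 would give a number within the scatter of the number for compound 4, which would be a second comparison of configuration in this series.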